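The compounds below may be only part of what the source reports. "The series", "measured", "known", "first", "only" and "open" are said of these compounds alone.

Among the measured compounds shown here, in a functional assay (CEM-VLB cells, Homo sapiens) for antiproliferative activity, read by sulforhodamine B assay, with a stated time of 48 h (on this read-out lower numbers stand for stronger inhibition and higher numbers for weaker inhibition), compound 1 `CCc1cccc(NS(=O)(=O)c2ccc(N3CCNC3=O)cc2)c1` gives 450 nM, the only exact number available for this small set of sulfonamides. Compound 2 `COc1cc(NS(=O)(=O)c2ccc(N3CCNC3=O)cc2)cc(OC)c1OC` is reported as > 250 nM, which is a limit and not a number. For the measured compounds named here, compound 1 therefore stands alone as a measured point, with no measured step to set it against.

The next compound to consider is compound 3 `Cc1ccc(C)c(NS(=O)(=O)c2ccc(N3CCNC3=O)cc2)c1`. It keeps the core of compound 1 and carries 2,5-dimethylphenyl in place of 3-ethylphenyl on a sulfonamide nitrogen. The two compounds have the same atoms, joined differently. Going by the values given here, no measured pair in this assay shows what a change of this kind does, so the direction cannot be read from the data and no shift beyond the usual scatter is expected. Among the compounds with values here, the expectation for compound 3 is anchored on compound 1 at 450 nM, the only number to hand. The estimated change is small, a 1.1-fold lower number from compound 1 to compound 3 (0.05 log units; within the scatter). For compound 3 the expected value is 400 nM, with an estimated range from 150 nM to 1100 nM.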

Compound 3, half-maximal inhibitory concentration: 120 nM
Beside the measured number, compound 3's estimate is 3.3-fold (0.52 log units) above it; the measured number lies below the stated range.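

In this assay, putting 2,5-dimethylphenyl in place of 3-ethylphenyl on a sulfonamide nitrogen gives a 3.8-fold lower number from compound 1 to compound 3 (0.57 log units; beyond the scatter). Among the compounds shown here, this is the first measured step in the set, and it shows that this position responds to how the carbons of the group are arranged, even though the group that leaves and the group that enters have the same count of heavy atoms, the same single aromatic ring of carbon and no net charge. Compound 2 is reported only as a limit and not as a number, so it offers no second step at this position: the limit of > 250 nM in this assay, at which 1 of the 3 values shown sits.

The compounds shown leave open whether the stronger inhibition of compound 3 depends on both methyl groups of 2,5-dimethylphenyl or on only one of them, since this single step changes the whole group at once. They also leave open how the same position would respond to a phenyl ring carrying an amine or a carboxylic acid, or to a longer chain such as butyl in place of the ethyl group of 3-ethylphenyl.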